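The source may hold more compounds than are shown below. What is called first, only, known or untested is meant among the compounds shown, and "the series" means these compounds.

Working notes on the series, with a physicochemical assay for acid dissociation, as the read-out. Compound 1 (`CN(Cc1ccccc1)Cc1ccccc1CNc1ccnc2cc(Cl)ccc12`) gives 7.57 and compound 2 (`CN(Cc1ccccc1)Cc1ccc(CNc2ccnc3cc(Cl)ccc23)cc1`) gives 7.56 while compound 3 (`COc1ccc(CN(C)Cc2cccc(CNc3ccnc4cc(Cl)ccc34)c2)cc1`) gives 7.38 in this measurement. Compound 2 lies within the scatter of both other compounds, so the numbers form one narrow band and give no order.

Compound 4 (`CN(Cc1ccc(CNc2ccnc3cc(Cl)ccc23)cc1)Cc1ccc(N(C)C)cc1`) has no number yet. It differs from compound 2 by one change (dimethylamino in place of hydrogen on an aromatic carbon) with dimethylamino in place of hydrogen on an aromatic carbon, para to a large group. Going by the values given here, no measured pair differs in one place, so no measured step speaks to this change. Among the compounds with values here, the band around compound 2 at 7.56 is the only guide, and no shift beyond the scatter is expected in this assay for this change. The expected size is a number 0.04 log units higher from compound 2 to compound 4 (within the scatter) and so stays within the scatter. Compound 4 is estimated at 7.6 with an expected range from 7.25 to 7.95 as its upper end.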

Compound 4, acid dissociation constant: 7.33
The estimate for compound 4 lay 0.27 log units above the measured number; the range from low to high includes it.
By their numbers in this assay, from the lowest: compounds 4, 3, 2 and 1 (each within the scatter of the next).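

In this assay, going by these compounds alone, the step of a number 0.23 log units lower from compound 2 to compound 4 (within the scatter) is the first one-place comparison, for dimethylamino in place of hydrogen on an aromatic carbon, para to a large group. Within the data shown here, at this position, then, a group of 3 heavy atoms with 1 hydrogen-bond acceptor and no net charge can enter with no shift beyond the scatter, which the earlier compounds, with no one-place step among them, could not show. No measured information bears on the reason for this result.

The compounds shown leave open whether a carboxylic acid or an aminoethyl chain at this same place would also stay within the scatter of compound 2. They also leave open whether dimethylamino would give a step of similar size on the corresponding ring of compound 1.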